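Changing the aromatic group on a shared core

The source may report more compounds than this note shows. Statements on the series, on what has been measured and on what is new or still open speak of the compounds shown alone.

Compound 1 `Cc1cc(C#N)cc(-c2c(C)nn(-c3nc(-c4ccc(Cl)c(Cl)c4)c(SC(C)C)s3)c2C(=O)O)c1` gives 4800 nM in a functional assay on BJAB cells (Homo sapiens) for antiproliferative activity, with a stated time of 4 days; on this read-out higher numbers stand for an effect only at larger amounts of compound and lower numbers for an effect already at smaller amounts.
Compound 2 `Cc1nn(-c2nc(-c3ccc(Cl)c(Cl)c3)c(SC(C)C)s2)c(C(=O)O)c1-c1ccncc1` gives 5900 nM in this assay.

Both compounds share the same core and differ only in the aromatic group attached to one carbon of the five-membered ring. On this read-out compound 2 has the highest of the two numbers, but its nearest neighbour, compound 1, lies so close that the two cannot be told apart: a 1.2-fold higher number from compound 1 to compound 2 (0.09 log units; within the scatter).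

Compound 3 `Cc1nn(-c2nc(-c3ccc(Cl)c(Cl)c3)c(SC(C)C)s2)c(C(=O)O)c1-c1ccc(Cl)cc1` has not yet been measured. It differs from compound 2 in one place: 4-chlorophenyl in place of pyridin-4-yl on an aromatic carbon.

Within the data shown here, the only measured step that bears on this exchange is the earlier swap of one aromatic group for another at the same position, and that step stayed within the scatter. Because a 1.2-fold higher number from compound 1 to compound 2 (0.09 log units; within the scatter) produced no change beyond the scatter, a further swap of this kind is expected to behave in the same way. For compound 3 the expected step is a 1.2-fold lower number from compound 2 to compound 3 (0.07 log units; within the scatter), that is, no step beyond the scatter. Compound 3 is therefore estimated at 5000 nM, with a likely range from 2200 nM to 12000 nM.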

Compound 3, half-maximal effective concentration: 2500 nM
Compound 3: the middle estimate sits 2.0-fold (0.30 log units) above what was measured, and the stated range covers the measured number.
By their numbers in this assay, from the lowest: compounds 3, 1 and 2 (each within the scatter of the next, the first and the last beyond it).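

In this assay, among these compounds, this position proves not to be indifferent to its aromatic group: 4-chlorophenyl in place of pyridin-4-yl gives a 2.4-fold lower number from compound 2 to compound 3 (0.37 log units; beyond the scatter) and so provides the first step here beyond the scatter, although a modest one. The same group in place of 3-cyano-5-methylphenyl gives a 1.9-fold lower number from compound 1 to compound 3 (0.28 log units; within the scatter) and stays within the scatter, so only the two ends of this small series, compound 2 and compound 3, can be told apart. The exchange from compound 2 to compound 3 swaps a ring nitrogen for carbon and adds a chlorine, but no measurement at hand explains the difference.

The compounds shown leave open whether the step follows the chlorine, the loss of the ring nitrogen or both, a question that an unsubstituted phenyl group or a 3-chlorophenyl group at this position could help to separate. They also leave open how groups of a different kind, such as an amine or a longer alkyl chain, would read on this aromatic carbon.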